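Benzylsulfanyl on the trimethoxyphenyl series: compound 4

A few compounds are considered here, and "the series" means these few. Any claim that something is new, unique, unknown or untested is made for them only; others in the source may bear on it.

Measured so far:
Compound 1, `CCc1nnc(SCc2ccccc2)n1N1C(=O)c2ccccc2C1=O`: in a functional assay on PC-3M cells (Homo sapiens) for cytotoxicity, read by MTT assay, with a stated time of 48 h (a higher number here means a weaker inhibitor, a lower number a stronger inhibitor), compound 1 gives > 200000 nM, a limit of the assay.
Compound 2, `COc1cc(-c2nnc(SCc3ccccc3Cl)n2N2C(=O)c3ccccc3C2=O)cc(OC)c1OC`: in this assay compound 2 gives > 200000 nM, a limit of the assay.
Compound 3, `COc1cc(-c2nnc(SC)n2N2C(=O)c3ccccc3C2=O)cc(OC)c1OC`: in this assay compound 3 gives > 200000 nM, a limit of the assay.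

Among the measured compounds shown here, compound 3 stands at the limit, as do the other two; every value shown sits at the limit of > 200000 nM in this assay, at which 3 of the 3 values shown sit, so no compound is separated from any other. For the measured compounds named here, the one measured step, a step that the two limits leave unreadable from compound 2 to compound 3, cannot be read: both ends are limits, and it gives no size in either direction.

Compound 4, `COc1cc(-c2nnc(SCc3ccccc3)n2N2C(=O)c3ccccc3C2=O)cc(OC)c1OC`, differs from compound 3 by phenyl in place of hydrogen on a saturated chain carbon bound to a sulfur. Compound 1 carries the same benzylsulfanyl group on a different core and sits at the limit. Compound 2 carries a closely related 2-chlorobenzyl group on the same core as compound 4 and sits at the limit. Nothing measured here suggests a step beyond the scatter. The step from compound 3 to compound 4 is therefore expected to be a step that the limit leaves unreadable from compound 3 to compound 4, that is, no readable change. Compound 4 is expected at 300000 nM, in the range 100000 nM to 1000000 nM, most likely reported again only as a limit.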

Compound 4, half-maximal inhibitory concentration: > 200000 nM
Compound 4: a limit, no number (the forecaster's own chance of this, stated with the estimate: 85%); the middle value lies beyond the limit too.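

In this assay compound 4 gives > 200000 nM as a limit of the assay. The steps to compound 4 from compound 1, compound 2 and compound 3 therefore cannot be read: the limit of > 200000 nM in this assay, at which 4 of the 4 values shown sit. The compounds shown leave open how far each lies beyond that limit, and whether any of these changes moves a value in this assay at all.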